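From 2-iodoethenyl to nitro on the shared core

The source may report more compounds than this note shows. Statements on the series, on what has been measured and on what is new or still open speak of the compounds shown alone.

Measured in an ADME assay on L1210/0 cells (Mus musculus) for cytotoxicity, with a stated time of 48 h; on this read-out lower numbers stand for stronger inhibition and higher numbers for weaker inhibition:
- compound 1 `O=c1[nH]c(=O)n([C@H]2C[C@H](O)[C@@H](CO)O2)cc1/C=N/O`: 15500 nM
- compound 2 `O=c1[nH]c(=O)n([C@H]2C[C@H](O)[C@@H](CO)O2)cc1/C=C/I`: 63900 nM

Of these two compounds, compound 2 holds the higher number, at 63900 nM. The next compound, compound 3 `O=c1[nH]c(=O)n([C@H]2C[C@H](O)[C@@H](CO)O2)cc1[N+](=O)[O-]`, has not yet been measured. It differs from compound 2 by one change, (nitro in place of 2-iodoethenyl on an aromatic carbon), which places nitro in place of 2-iodoethenyl on an aromatic carbon. Among the measured compounds shown here, only one measured step bears on this: a 4.1-fold higher number from compound 1 to compound 2 (0.62 log units; beyond the scatter), which brought in 2-iodoethenyl and lies beyond the scatter. Nitro, like the group it replaced there, contains nitrogen and oxygen, so removing 2-iodoethenyl may reverse that modest rise, although a single step is thin support. A modest step to a lower number is therefore expected in this assay. The expected step is a 5.3-fold lower number from compound 2 to compound 3 (0.73 log units; beyond the scatter). For compound 3 the estimated value is 12000 nM, with an expected range from 1500 nM to 60000 nM.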

Compound 3, half-maximal inhibitory concentration: 130 nM
Compound 3: the middle estimate sits 92-fold (1.97 log units) above what was measured; the measured number lies below the stated range.
By their numbers in this assay, from the lowest: compound 3; then compound 1; then compound 2.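

In this assay, nitro on this aromatic carbon gives a 490-fold lower number from compound 2 to compound 3 (2.69 log units; beyond the scatter) and thus shows that this position can move the number far more than the earlier pair revealed. The change also gives a 120-fold lower number from compound 1 to compound 3 (2.08 log units; beyond the scatter), so the low number does not follow merely from removing 2-iodoethenyl or from placing nitrogen and oxygen at this position. All three groups hold the same count of heavy atoms, so that count does not separate them, and no measurement shown here explains why nitro stands apart.

Whether the low number is particular to nitro remains open, as other small groups at this position, such as an amine, a nitrile or a single chlorine atom, do not appear among these compounds. On these data alone, the effect of a carboxylic acid or a longer chain here also remains unknown.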